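A Third Dichlorobenzyl Ether Awaits Its Number

The source may hold more compounds than are shown below. What is called first, only, known or untested is meant among the compounds shown, and "the series" means these compounds.

Of the compounds shown here, two with a shared core have been tested in a functional assay on I10 cells (Mus musculus) for inhibition, read by MTT assay, with a stated time of 72 h; a higher number here means a weaker inhibitor, a lower number a stronger inhibitor. Among the measured compounds shown here, compound 1 `C=CCc1ccc(O)c(-c2ccc(OCc3ccc(Cl)c(Cl)c3)c(CC=C)c2)c1` gives 12300 nM, and compound 2 `C=CCc1ccc(O)c(-c2ccc(OCc3c(Cl)cccc3Cl)c(CC=C)c2)c1` gives 16600 nM, so compound 2 stands within the scatter of the only other number available. Compound 3 `C=CCc1ccc(O)c(-c2ccc(OCc3ccc(Cl)cc3Cl)c(CC=C)c2)c1` has not yet been measured. Its difference from compound 2 is 2,4-dichlorophenyl in place of 2,6-dichlorophenyl on a saturated chain carbon bound to an oxygen on an aromatic ring, which means 2,4-dichlorophenyl in place of 2,6-dichlorophenyl on a saturated chain carbon bound to an oxygen on an aromatic ring. For the measured compounds named here, one measured step bears on this change, as it also exchanges one dichlorophenyl for another at the same place. With a 1.3-fold higher number from compound 1 to compound 2 (0.13 log units; within the scatter) as that only step, no step beyond the scatter is expected in either direction in this assay. The estimated step is a 1.2-fold lower number from compound 2 to compound 3 (0.07 log units; within the scatter). The value expected for compound 3 is 14000 nM, within an estimated range of 7500 nM to 26000 nM.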

Compound 3, half-maximal inhibitory concentration: 10400 nM
Estimate against measurement, compound 3: 1.3-fold (0.13 log units) above; measured number inside the range.
By their numbers in this assay, from the lowest: compounds 3, 1 and 2 (each within the scatter of the next).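

Replacing 2,6-dichlorophenyl with 2,4-dichlorophenyl on the saturated chain carbon bound to an oxygen on an aromatic ring gives a 1.6-fold lower number from compound 2 to compound 3 (0.20 log units; within the scatter) in this assay, and replacing 3,4-dichlorophenyl with the same group gives a 1.2-fold lower number from compound 1 to compound 3 (0.07 log units; within the scatter). With three dichlorophenyl groups now read at this place, every step among them lies within the scatter, so this assay separates none of these chlorine arrangements. No other measurement is at hand that could account for this result.

As far as these compounds go, all three compounds carry two chlorines on this phenyl ring, so it remains open whether unsubstituted phenyl, a single chlorine, methoxy or a pyridine ring here would give a step beyond the scatter. The same question stands for a longer chain in place of the saturated chain carbon, and for an amine or a carboxylic acid on the ring.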